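The compounds below may be only part of what the source reports. "The series", "measured", "known", "first", "only" and "open" are said of these compounds alone.

Compound 1 `CCC1C(=O)N(C)c2cnc(-n3ccc4cc(C(=O)NC(C)C)ccc43)nc2N1c1ccn(C)n1` in an assay for inhibition of serine/threonine-protein kinase PLK3 (Homo sapiens), read by FRET and Z'-LYTE, with a stated time of 1 h (on this read-out lower numbers stand for stronger inhibition and higher numbers for weaker inhibition), gives > 10000 nM, which is a limit of the assay.
Compound 2 `CCC1C(=O)N(C)c2cnc(-n3ccc4cc(C(=O)NC)ccc43)nc2N1c1ccn(C)n1` in this assay gives > 10000 nM, again a limit.
Compound 3 `CCCCNC(=O)c1ccc2c(ccn2-c2ncc3c(n2)N(c2ccn(C)n2)C(CC)C(=O)N3C)c1` in this assay gives > 10000 nM, also a limit.

Compound 3 therefore stands at the limit of > 10000 nM in this assay, at which 3 of the 3 values shown sit, and no number separates it from the other two. The steps among the measured compounds are accordingly unreadable: a step that the two limits leave unreadable from compound 1 to compound 2, a step that the two limits leave unreadable from compound 1 to compound 3 and a step that the two limits leave unreadable from compound 2 to compound 3 cannot be sized because every value sits at the limit of > 10000 nM in this assay, at which 3 of the 3 values shown sit. These three steps all alter the alkyl group on the amide-type nitrogen of the shared core, and none of them moved a value off the limit.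

Compound 4 `CCNC(=O)c1ccc2c(ccn2-c2ncc3c(n2)N(c2ccn(C)n2)C(CC)C(=O)N3C)c1` differs from compound 3 by hydrogen in place of ethyl on a saturated chain carbon, two bonds along the chain from an amide-type nitrogen. Among the compounds with values here, the change shortens the same chain that the steps from compound 2 to compound 3 and from compound 1 to compound 3 lengthened or reshaped, so those are the steps that bear on it, and each of them left the read-out unchanged at the limit. No readable step in either direction can be expected from this change. Compound 4 is therefore expected at 15000 nM, with a range from 5000 nM to 50000 nM. The expected step is a step that the limit leaves unreadable from compound 3 to compound 4, which most likely means another limit rather than a number.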

Compound 4, half-maximal inhibitory concentration: > 10000 nM
Compound 4 ended at the assay's limit; the forecaster's own chance of this, stated with the estimate: 85%; the middle value is on the limit's open side.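

Compound 4 joins compound 1, compound 2 and compound 3 at a limit of the assay, so no new step can be read among these compounds: (the limit of > 10000 nM in this assay, at which 4 of the 4 values shown sit).

The compounds shown leave open how the four compare with one another, and whether any other alkyl group on the amide-type nitrogen of the shared core would give a readable number.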